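The source may report more compounds than this note shows. Statements on the series, on what has been measured and on what is new or still open speak of the compounds shown alone.

Of the compounds shown here, three built on one shared core have been tested in a functional assay on the whole organism with Rattus norvegicus as the target, at a dose of 20 mg/kg by the intraperitoneal route; a higher number here means more inhibition at the dose given (going by the name of the read-out), a lower number less inhibition. Compound 1 `Nc1nc(N)nc(-c2cc(F)ccc2Cl)n1` gives 78% in this assay. Compound 2 `Nc1nc(N)nc(-c2cc(Br)ccc2Cl)n1` gives 86% in this assay. Compound 3 `Nc1nc(N)nc(-c2cc(Cl)ccc2Br)n1` gives 81% in this assay. Compound 2 and compound 3 are made of the same atoms joined differently; the difference between the two cores is not broken down here. Compound 2 and compound 1, by contrast, differ in a single place: fluoro in place of bromo on an aromatic carbon. That exchange produced a number 8 percentage points lower from compound 2 to compound 1 (within the scatter), so the two numbers cannot be told apart.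

Compound 4 `Nc1nc(N)nc(-c2cc(Cl)ccc2F)n1` has not yet been measured. It differs from compound 3 by the same kind of change: fluoro in place of bromo on an aromatic carbon. The surroundings are not identical, though. In the change from compound 2 to compound 1 the carbon carrying the halogen is meta to a group of 8 heavy atoms, whereas in the change from compound 3 to compound 4 it is ortho to a group of 8 heavy atoms; in both cases it is para to a chloro group.

Resting on the earlier step of a number 8 percentage points lower from compound 2 to compound 1 (within the scatter), a similar small shift is expected, namely a number 6 percentage points lower from compound 3 to compound 4 (within the scatter). Compound 4 is therefore expected to give about 75% in this assay, most likely between 60% and 88%.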

Compound 4, a percentage reported as inhibition, in the whole organism at one dose (the size of the read-out at that dose, not a potency): 89%
Beside the measured number, compound 4's estimate is 14 percentage points below it, and the stated range ends below it.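

In this assay, fluoro in place of bromo gave a number 8 percentage points higher from compound 3 to compound 4 (within the scatter) and, taken alone, this step is too small to separate the two compounds. Set beside the earlier step, however, it shows that the same exchange does not carry over from one core to the other as one fixed shift, so a step read on one core is a poor guide to the other in this series: the same change on two cores in this assay, a number 8 percentage points lower (within the scatter) from compound 2 to compound 1 and a number 8 percentage points higher (within the scatter) from compound 3 to compound 4, 16 percentage points apart, beyond the scatter of two such steps. Within the data shown here, this does not show why the two steps part, whether the surroundings of the exchanged halogen matter or something else does, and neither does it show that fluoro is better or worse than bromo on either core, since each core offers only a single pair and each step on its own lies within the scatter.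

All four compounds shown carry only halogens on the aromatic ring, so it stays open how a methyl group, a methoxy group, a trifluoromethyl group or an amine in place of those halogens would behave in this assay. The read-out also comes from a single dose, which leaves open how these compounds would compare at other doses.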